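The compounds below may be only part of what the source reports. "The series", "measured", "known", "first", "only" and "open" are said of these compounds alone.

Measured so far in an ADME assay on HeLa cells (Homo sapiens) for cytotoxicity, read by MTT assay, with a stated time of 24 h; on this read-out higher numbers stand for weaker inhibition and lower numbers for stronger inhibition:
compound 1, `CN(C)C(=S)SC(=S)N1CCN(c2cccc(Cl)c2)CC1`
compound 2, `CCSC(=S)N1CCN(C(=S)SC(=S)N(C)C)CC1`

In this assay compound 2 gives 4480000 nM. For compound 1 the entry is a limit only, > 5000000 nM, and not a number. Within the data shown here, compound 2 thus holds the only number; the other entry is the limit (the limit of > 5000000 nM in this assay, at which 1 of the 2 values shown sits). Among the measured compounds shown here, the single step that can be read, an at least 1.1-fold lower number from compound 1 to compound 2 (0.04 log units; that floor lies within the scatter), sits at the floor of the scatter and gives no direction.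

Compound 3 is `CCCCSC(=S)N1CCN(C(=S)SC(=S)N(C)C)CC1`, not yet measured. It differs from compound 2 by ethyl in place of hydrogen on a saturated chain carbon, two bonds along the chain from a sulfur. For the measured compounds named here, no measured step touches this part of the molecule: the only measured step exchanges the group on the amine nitrogen in the ring and leaves the ethylsulfanyl group untouched. There is therefore nothing in this assay to suggest a step beyond the scatter from compound 2 to compound 3, and the result may again come back as a limit rather than a number. The expected step is a 1.3-fold lower number from compound 2 to compound 3 (0.11 log units; within the scatter). Compound 3 is estimated at 3500000 nM, within 1500000 nM to 8000000 nM.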

Compound 3, half-maximal inhibitory concentration: > 5000000 nM
Compound 3: a limit, no number (the forecaster's own chance of this, stated with the estimate: 35%); at least 1.4-fold (0.15 log units) between middle value and limit.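

In this assay compound 3 gives > 5000000 nM, which is a limit and not a number. Among these compounds, this is the first reading at this position: ethyl in place of hydrogen on a saturated chain carbon, two bonds along the chain from a sulfur, the change from ethylsulfanyl to butylsulfanyl, gives an at least 1.1-fold higher number from compound 2 to compound 3 (0.04 log units; that floor lies within the scatter), so only a floor can be read, its true size remains open, and no lower number appears with butylsulfanyl. The step involving compound 1 and compound 3 cannot be read, and the limit now holds most of the series: the limit of > 5000000 nM in this assay, at which 2 of the 3 values shown sit.

Among the compounds shown here, compound 2 remains the only compound with a number, so no change on this chain has a measured size yet. From the compounds shown here alone, whether a chain longer than butyl, or a chain carrying an amine or a carboxylic acid, would give a number clearly lower than that of compound 2 in this assay stays open.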